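The compounds below may be only part of what the source reports. "The series", "measured", "known", "first", "only" and "open" are said of these compounds alone.

The compounds share one core, carried here by compound 1 `Nc1cccc(-c2cn3nc(-c4cccs4)sc3n2)c1`, compound 2 `CCc1ccc(-c2nn3cc(-c4cccc(N)c4)nc3s2)cc1` and compound 3 `C=C(Br)C(=O)Nc1cccc(-c2cn3nc(Cc4cccc(OC)c4)sc3n2)c1`. In a functional assay on FM3A cells (Mus musculus) for inhibition, read by cell counting, with a stated time of 2 days (a lower number here means a stronger inhibitor, a higher number a weaker inhibitor), compound 1 gives only a limit of the assay, > 250000 nM, as described by the limit of > 250000 nM in this assay, at which 1 of the 3 values shown sits. In this assay compound 2 gives 8200 nM. Compound 3, the one bearing the acrylamide on the aniline and a benzyl group on the core, gives 1100 nM in this assay, which places it at the lowest of the two numbers shown, and its gap to compound 2 lies beyond the scatter of the assay.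

The step that follows leads to compound 4 `C=C(Br)C(=O)Nc1cccc(-c2cn3nc(Cc4ccc(Cl)cc4)sc3n2)c1`. It keeps everything else of compound 3 and changes only the benzyl group: 4-chlorophenyl in place of 3-methoxyphenyl on a saturated chain carbon bound to an aromatic carbon. Among the measured compounds shown here, no measured pair in this set differs in this way, so no direct precedent is available; the two substituents are of similar size and both are simple substituted phenyl rings on the same saturated chain carbon. The expectation is therefore a step from compound 3 to compound 4 of a 1.2-fold higher number from compound 3 to compound 4 (0.07 log units; within the scatter), that is, no change beyond the usual scatter in either direction. On that basis compound 4 is estimated at 1300 nM in this assay, with a likely range from 400 nM to 4500 nM.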

Compound 4, half-maximal inhibitory concentration: 1100 nM
Compound 4: the middle estimate sits 1.2-fold (0.07 log units) above what was measured; measured number inside the range.
By their numbers in this assay, from the lowest: compounds 3 and 4 (each within the scatter of the next); then compound 2. At a limit, above all of these: compound 1.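

In this assay, the benzyl group of the shared core, on a saturated chain carbon bound to an aromatic carbon, takes 4-chlorophenyl in place of 3-methoxyphenyl with no change at the digits printed from compound 3 to compound 4 (within the scatter). Among the compounds shown here, this is the first pair in the set that differs in one place, and it shows that this position accepts a change of both the substituent and its place on the ring, from methoxy to chlorine, without a step the assay can distinguish from scatter. Nothing shown here bears on why the two benzyl groups cannot be told apart, and this one pair cannot separate the effect of the substituent from that of its place on the ring.

On these data alone, whether a stronger or weaker inhibitor results from an amine or a carboxylic acid on this phenyl ring, or from a longer chain in place of the single saturated carbon, remains open. Also open is what the acrylamide on the aniline contributes, since no pair shown differs in that place alone, and a compound with the free aniline and a 4-chlorobenzyl group would be needed to read it.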